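The source may hold more compounds than are shown below. What is called first, only, known or untested is meant among the compounds shown, and "the series" means these compounds.

Compound 1 `CC1=CC[C@@H]([C@@](C)(O)CCCC(C)(C)NC(=S)N/N=C\c2ccc(N(C)C)cc2)CC1` was tested in a functional assay on PCO3 cells (Homo sapiens) for cytotoxicity, read by sulforhodamine B assay; a lower number here means a stronger inhibitor of growth, a higher number a weaker inhibitor of growth. In this assay compound 1 returns only the limit > 100000 nM, so where it stands is known as that limit alone. Two companions share the same core and differ from it only in the aryl group on the carbon with a double bond to nitrogen. Compound 2 `CC1=CC[C@@H]([C@@](C)(O)CCCC(C)(C)NC(=S)N/N=C\c2ccccc2[N+](=O)[O-])CC1` likewise gives no number in this assay but the limit > 100000 nM. Compound 3 `CC1=CC[C@@H]([C@@](C)(O)CCCC(C)(C)NC(=S)N/N=C\c2ccc([N+](=O)[O-])cc2)CC1` also reaches only the limit > 100000 nM in this assay. The steps among the three are accordingly not readable: a step that the two limits leave unreadable from compound 1 to compound 2, a step that the two limits leave unreadable from compound 1 to compound 3 and a step that the two limits leave unreadable from compound 2 to compound 3. All of the values sit at the limit of > 100000 nM in this assay, at which 3 of the 3 values shown sit.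

Compound 4 `CC1=CC[C@@H]([C@@](C)(O)CCCC(C)(C)NC(=S)N/N=C\c2cccc(Cl)c2)CC1` has not yet been measured in this assay. It differs from compound 1 as follows: 3-chlorophenyl in place of 4-(dimethylamino)phenyl on a carbon with a double bond to nitrogen. Among the compounds with values here, no measured step bears readably on this change; each rests on two limits. What the three measured compounds do show is that three different aryl groups at this position all left total growth inhibition outside the tested range. Compound 4 is expected to behave in the same way. The step of a number no higher from compound 1 to compound 4 (the limit leaves the size open) is expected to be no real change. The estimate for compound 4 in this assay is 100000 nM, within 30000 nM to 300000 nM, and most likely only a limit will again be reported.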

Compound 4, concentration for total growth inhibition: 37800 nM
Estimate against measurement, compound 4: 2.6-fold (0.42 log units) above; the measured number falls inside the stated range.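

In this assay, within the data shown here, the group on the carbon with a double bond to nitrogen proved able to bring total growth inhibition within a measurable range, something the earlier compounds could not show: 3-chlorophenyl gives an at least 2.6-fold lower number from compound 1 to compound 4 (0.42 log units; beyond the scatter), replacing 4-(dimethylamino)phenyl, as well as an at least 2.6-fold lower number from compound 2 to compound 4 (0.42 log units; beyond the scatter), replacing 2-nitrophenyl, and an at least 2.6-fold lower number from compound 3 to compound 4 (0.42 log units; beyond the scatter), replacing 4-nitrophenyl. Each of these steps has a limit at one end, so it fixes only the smallest possible size and leaves the full size open, while the steps among compounds 1, 2 and 3 still cannot be read. Compound 4 therefore stands apart as the one compound here with a number, while the other three remain at a limit: the limit of > 100000 nM in this assay, at which 3 of the 4 values shown sit.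

The compounds shown leave open whether the gain depends on the chlorine at all, as a plain phenyl, or a fluorine or bromine in place of the chlorine, would be needed to test this. They also leave open how far compounds 1, 2 and 3 actually lie from compound 4, and whether the three differ from one another.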